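The source may report more compounds than this note shows. Statements on the series, on what has been measured and on what is new or still open speak of the compounds shown alone.

In a functional assay for binding affinity to metabotropic glutamate receptor 2 (Homo sapiens), read by GTPgammaS binding (a higher number here means that more compound is needed for the effect, a lower number that less compound is needed), the three measured compounds stand as follows:

compound 1 `Cc1c(OCCCCOc2ccccc2)ccc(C(=O)CC(C)C)c1O`: 4550 nM
compound 2 `Cc1c(OCCCCOc2cccnc2)ccc(C(=O)CC(C)C)c1O`: 1720 nM
compound 3 `Cc1c(OCCCCOc2ccncc2)ccc(C(=O)CC(C)C)c1O`: 3860 nM

Compound 3 holds the second highest of the three numbers. Its nearest neighbour is compound 1, a 1.2-fold lower number from compound 1 to compound 3 (0.07 log units; within the scatter), so the two are not separated. Compound 2 sits apart: a 2.2-fold higher number from compound 2 to compound 3 (0.35 log units; beyond the scatter), and against compound 1 the step was a 2.6-fold lower number from compound 1 to compound 2 (0.42 log units; beyond the scatter).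

Compound 4 `Cc1c(OCCCCSc2ccccn2)ccc(C(=O)CC(C)C)c1O` is the next one. Its difference from compound 3 is (pyridin-2-yl)sulfanyl in place of (pyridin-4-yl)oxy on a saturated chain carbon, four bonds along the chain from an oxygen on an aromatic ring. The three measured steps all concern where the ring nitrogen sits while the linker stays an oxygen, and the largest of them was modest. None of them touches an oxygen-to-sulfur exchange in the linker, nor a pyridin-2-yl ring, so they only set the scale: shifts of that order, in either direction, are what the series has shown so far. A modest step is expected, direction open, with no firm reason to expect more than the scatter.

Compound 4 is thus expected to give 3200 nM in this assay, with a range of 1200 nM to 8500 nM. That amounts to an expected 1.2-fold lower number from compound 3 to compound 4 (0.08 log units; within the scatter).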

Compound 4, half-maximal effective concentration: 1530 nM
Beside the measured number, compound 4's estimate is 2.1-fold (0.32 log units) above it; low and high end bracket the measured number.
By their numbers in this assay, from the lowest: compounds 4 and 2 (each within the scatter of the next); then compounds 3 and 1 (each within the scatter of the next).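

In this assay, for the compounds shown here, the exchange to (pyridin-2-yl)sulfanyl on this saturated chain carbon, the only change that puts sulfur in the linker, gives a modest step from the (pyridin-4-yl)oxy group (a 2.5-fold lower number from compound 3 to compound 4 (0.40 log units; beyond the scatter)) and a modest step from phenoxy (a 3.0-fold lower number from compound 1 to compound 4 (0.47 log units; beyond the scatter)), the largest step so far. Against the (pyridin-3-yl)oxy group the step stays within the scatter (a 1.1-fold lower number from compound 2 to compound 4 (0.05 log units; within the scatter)), so at this position a sulfur-linked pyridin-2-yl ring and an oxygen-linked pyridin-3-yl ring are not separated. Nothing measured here accounts for the size of these steps.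

Linker atom and ring nitrogen position change together in compound 4, so their shares cannot be separated; (pyridin-2-yl)oxy and (pyridin-3-yl)sulfanyl would divide them. Also open, from the compounds shown here alone, is how a longer chain, or an amine in place of the terminal ring, would read in this assay at this position.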